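Benzyloxy in Place of Nitro: A Repeated Change

The source may report more compounds than this note shows. Statements on the series, on what has been measured and on what is new or still open speak of the compounds shown alone.

Compound 1 `CCOC(=O)c1cc(-c2cc(OC)c(OC)c(OC)c2)c(-c2ccc(OC)c([N+](=O)[O-])c2)s1`: 15800 nM
Compound 2 `CCOC(=O)c1cc(-c2cc(OC)c(OC)c(OC)c2)c(-c2ccc(OC)c(OCc3ccccc3)c2)s1`: > 100000 nM, a limit of the assay rather than a number
Compound 3 `COc1ccc(-c2ccsc2-c2cc(OC)c(OC)c(OC)c2)cc1[N+](=O)[O-]`: 21000 nM

All three were tested in a functional assay on KB cells (Homo sapiens) for antiproliferative activity, read by MTT assay, with a stated time of 72 h; on this read-out lower numbers stand for stronger inhibition and higher numbers for weaker inhibition. Compound 2 sits at the limit of > 100000 nM in this assay, at which 1 of the 3 values shown sits. Compound 1 and compound 3 lie within the usual scatter of each other, so no order between them is claimed. The change from compound 1 to compound 2 is benzyloxy in place of nitro on an aromatic carbon; it made an at least 6.3-fold higher number from compound 1 to compound 2 (0.80 log units; beyond the scatter).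

Compound 4 `COc1ccc(-c2ccsc2-c2cc(OC)c(OC)c(OC)c2)cc1OCc1ccccc1` has not yet been measured. For the measured compounds named here, it differs from compound 3 by benzyloxy in place of nitro on an aromatic carbon, the same change at the same place as the one between compound 1 and compound 2. How the core of compound 3 differs from the core of compound 1 is not broken down here.

In this assay the estimated step for compound 4 is a 6.7-fold higher number from compound 3 to compound 4 (0.82 log units; beyond the scatter), because the same change earlier gave an at least 6.3-fold higher number from compound 1 to compound 2 (0.80 log units; beyond the scatter). Compound 4 is therefore expected to give about 140000 nM, most likely between 60000 nM and 400000 nM, and quite possibly only a limit of the assay.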

Compound 4, half-maximal inhibitory concentration: > 100000 nM
Compound 4 ended at the assay's limit; the forecaster's own chance of this, stated with the estimate: 60%; the middle value lies beyond the limit too.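

Swapping nitro for benzyloxy gave an at least 4.7-fold higher number from compound 3 to compound 4 (0.67 log units; beyond the scatter) in this assay, so the change again moved the read-out towards weaker inhibition. On the two cores shown, it therefore carried over in direction, but the results cannot show whether it carried over in size: the same change on two cores in this assay, an at least 6.3-fold higher number (0.80 log units; beyond the scatter) from compound 1 to compound 2 and an at least 4.7-fold higher number (0.67 log units; beyond the scatter) from compound 3 to compound 4; the limit leaves it open whether they differ This rests on only two pairs of compounds, and the true values of compound 2 and compound 4 remain unknown, as both ended at a limit of the assay rather than at a number: the limit of > 100000 nM in this assay, at which 2 of the 4 values shown sit.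

The compounds shown leave open how an amine or a carboxylic acid would read out in the place of the nitro, and whether a small ether such as ethoxy would already reach the limit. They also leave open whether the same step would appear on any core other than these two.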